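A few compounds are considered here, and "the series" means these few. Any claim that something is new, unique, unknown or untested is made for them only; others in the source may bear on it.

In a functional assay on MDA-MB-231 cells (Homo sapiens) for cytotoxicity, read by MTT assay, with a stated time of 72 h (a higher number here means a weaker inhibitor, a lower number a stronger inhibitor), compound 1 (`Nc1ccccc1NC(=O)c1ccc(NC(=S)NCc2cccc(F)c2)cc1`) gives 74000 nM. Compound 2 (`Nc1ccccc1NC(=O)c1ccc(CNC(=O)c2cc3cnccc3[nH]2)cc1`) gives 48000 nM, which lies within the usual scatter of compound 1, so these two cannot be told apart. Compound 3 (`Nc1ccccc1NC(=O)c1ccc(NC(=O)/C(Cl)=C(\Cl)c2cccnc2)cc1`) gives 13000 nM, a lower number than compound 1 by more than the scatter, which makes it the stronger inhibitor of that pair.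

Compound 4 (`Cc1ccc(CNC(=S)Nc2ccc(C(=O)Nc3ccccc3N)cc2)cn1`) keeps the rest of compound 1 and changes one group: 6-methylpyridin-3-yl in place of 3-fluorophenyl on a saturated chain carbon bound to an amide-type nitrogen. For the measured compounds named here, no two measured compounds differ in only one place, so nothing here shows directly what such a swap does. The expectation therefore stays anchored to compound 1 at 74000 nM, with no change beyond the scatter. The estimated step is a 1.5-fold lower number from compound 1 to compound 4 (0.17 log units; within the scatter), which is small and slightly downward. For compound 4, the expected value is 50000 nM, with an estimated range of 20000 nM to 100000 nM.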

Compound 4, half-maximal inhibitory concentration: 63000 nM
Compound 4: middle estimate off by 1.3-fold (0.10 log units), on the low side, within the range that was stated.
By their numbers in this assay, from the lowest: compound 3; then compounds 2, 4 and 1 (each within the scatter of the next).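

For the compounds shown here, this is the first direct look at this place, on a saturated chain carbon bound to an amide-type nitrogen. In this assay, putting 6-methylpyridin-3-yl in place of 3-fluorophenyl gives a 1.2-fold lower number from compound 1 to compound 4 (0.07 log units; within the scatter), so this exchange of one aromatic ring for another, which adds a hydrogen-bond acceptor, leaves no difference that can be told from the scatter. Nothing measured here offers an explanation for that outcome.

The swap changes the fluorine, the ring nitrogen and the methyl group all at once, so their separate contributions cannot be pulled apart; an unsubstituted phenyl or pyridin-3-yl ring would be needed to do so. On these data alone, it also remains open whether a very different group at this place, such as a carboxylic acid or an amine, would move the number beyond the scatter.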